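The compounds below may be only part of what the source reports. "The series", "measured", "known", "first", "only" and "open" are said of these compounds alone.

Measured so far:
Compound 1 `CCN(CC)CCCC(C)/N=C(/N)NC(=O)c1cccc(Cl)c1CCc1cc(Br)ccc1OC` — 0.83 nM
Compound 2 `CCN(CC)CCCC(C)/N=C(/N)NC(=O)c1cccc(F)c1OCc1cc(Br)ccc1OC` — 900 nM
Compound 3 `CCN(CC)CCCC(C)/N=C(/N)NC(=O)c1cccc(F)c1CCc1cc(Br)ccc1OC` — 4.3 nM

In an assay for binding affinity to Melanocortin receptor 4 (Homo sapiens) (on this read-out higher numbers stand for weaker inhibition and lower numbers for stronger inhibition), compound 3 stands second highest of the three numbers; its nearest neighbour is compound 1, and the gap between them is a 5.2-fold higher number from compound 1 to compound 3 (0.71 log units; beyond the scatter), while the gap to compound 2 is far wider, a 210-fold lower number from compound 2 to compound 3 (2.32 log units; beyond the scatter). Compound 4 `CCN(CC)CCCC(C)/N=C(/N)NC(=O)c1cccc(F)c1CCc1cccc2ccccc12` has not been measured. It differs from compound 3 in one place: naphthalen-1-yl in place of 5-bromo-2-methoxyphenyl on a saturated chain carbon, two bonds along the chain from an aromatic carbon. Neither measured step bears directly on this change, since one concerns a halogen on the core and the other the linker. With no guide, the step is estimated to be a 7.0-fold higher number from compound 3 to compound 4 (0.84 log units; beyond the scatter), toward a higher number. Compound 4 is therefore expected to give about 30 nM, within a range from 5 nM to 200 nM.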

Compound 4, inhibition constant: 89 nM
Compound 4: the middle estimate sits 3.0-fold (0.47 log units) below what was measured; the range from low to high includes it.
By their numbers in this assay, from the lowest: compound 1; then compound 3; then compound 4; then compound 2.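

In this assay, within the data shown here, the swap on the saturated chain carbon gives a 21-fold higher number from compound 3 to compound 4 (1.32 log units; beyond the scatter), so the aryl group at the far end of the chain matters to the read-out, which the earlier steps on the core halogen and the linker could not show. The 5-bromo-2-methoxyphenyl group of compound 3 is clearly preferred here over naphthalen-1-yl. No available evidence accounts for this difference. Still open, as far as these compounds go, is whether the bromine, the methoxy or both carry the preference, as both leave together in this step. A 2-methoxyphenyl or 3-bromophenyl group at this place would separate the two.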